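The source may report more compounds than this note shows. Statements on the series, on what has been measured and on what is new or still open speak of the compounds shown alone.

Values in a functional assay; a lower number here means a stronger inhibitor, a higher number a weaker inhibitor:
- compound 1 `CC(C)=CCOc1ccc2c(c1)OC(c1ccccc1Cl)CC2=O`: 8020 nM
- compound 2 `CC(C)=CCOc1cc(O)c2c(c1)OC(c1cccc(F)c1)CC2=O`: 7240 nM
- compound 3 `CC(C)=CCOc1cc(O)c2c(c1)OC(c1ccccc1Cl)CC2=O`: 4270 nM

Compound 3 stands at 4270 nM, within the scatter of both other compounds. The next step leads to compound 4 `CC(C)=CCOc1cc(O)c2c(c1)OC(c1cccc(Br)c1)CC2=O`, with 3-bromophenyl in place of 2-chlorophenyl on a saturated ring carbon. Among the compounds with values here, the only measured change of the group on that carbon is a 1.7-fold lower number from compound 2 to compound 3 (0.23 log units; within the scatter), which stays within the scatter. The hydroxy step, a 1.9-fold lower number from compound 1 to compound 3 (0.27 log units; within the scatter), does not touch that carbon and bears on it only weakly. Within the data shown here, no compound carrying 3-bromophenyl has been measured. In this assay the expected outcome is no change beyond the scatter, with an estimated 1.2-fold higher number from compound 3 to compound 4 (0.07 log units; within the scatter). Compound 4 is estimated at 5000 nM, with an expected range of 2500 nM to 10000 nM.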

Compound 4, half-maximal inhibitory concentration: 4040 nM
Compound 4: the middle estimate sits 1.2-fold (0.09 log units) above what was measured; the measured number falls inside the stated range.
By their numbers in this assay, from the lowest: compounds 4, 3, 2 and 1 (each within the scatter of the next).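

In this assay, the phenyl on the saturated ring carbon next to the ring oxygen now has a second and third exchange, and neither leaves the scatter: a 1.1-fold lower number from compound 3 to compound 4 (0.02 log units; within the scatter), and a 1.8-fold lower number from compound 2 to compound 4 (0.25 log units; within the scatter). Across these halogen-bearing phenyl groups, compound 2, compound 3 and compound 4 therefore show no separation at this position. No measurement available here explains this result. From the compounds shown here alone, whether an amine or a carboxylic acid on this phenyl would move the number beyond the scatter stays open. So does the effect of a longer chain in place of the ether chain on the shared core.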